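Chain-end amine replacement: expectation for compound 4

The source may hold more compounds than are shown below. What is called first, only, known or untested is meant among the compounds shown, and "the series" means these compounds.

Compound 1 `CCN(CC)CCCOc1cc2ncnc(Nc3ccc(C#N)cc3)c2cc1OC`, compound 2 `COc1cc2c(Nc3ccc(C#N)cc3)ncnc2cc1OCCCN(C)Cc1ccccc1` and compound 3 `COc1cc2c(Nc3ccc(C#N)cc3)ncnc2cc1OCCCN1CCC(c2ccccc2)CC1` share one core and differ only in the group on a saturated chain carbon, three bonds along the chain from an oxygen on an aromatic ring. In a functional assay on A549 cells (Homo sapiens) for antiproliferative activity, read by MTT assay, with a stated time of 72 h (a higher number here means a weaker inhibitor, a lower number a stronger inhibitor), compound 1 gives 50600 nM and compound 3 gives 9500 nM. For compound 2 the result in this assay is only a limit, > 100000 nM, so compound 2 stands at the limit of > 100000 nM in this assay, at which 1 of the 3 values shown sits, and no number beyond that is known for it.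

Compound 4 `COc1cc2c(Nc3ccc(C#N)cc3)ncnc2cc1OCCCN1CCN(c2ccncc2)CC1` carries a change at the same place: 4-(pyridin-4-yl)piperazin-1-yl in place of benzyl(methyl)amino on a saturated chain carbon, three bonds along the chain from an oxygen on an aromatic ring. Within the data shown here, two measured steps bear on it. The step of an at least 10-fold lower number from compound 2 to compound 3 (1.02 log units; beyond the scatter) and the step of a 5.3-fold lower number from compound 1 to compound 3 (0.73 log units; beyond the scatter) both replaced the chain-end group and both gave lower numbers; the step of an at least 1.9-fold higher number from compound 1 to compound 2 (0.29 log units; that floor lies within the scatter) stayed within the scatter floor. Another replacement of benzyl(methyl)amino is therefore expected to give a lower number in this assay, of a size comparable to an at least 5.0-fold lower number from compound 2 to compound 4 (0.69 log units; beyond the scatter), though this rests on only two informative steps.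

Compound 4 is estimated at 20000 nM, with a range from 5000 nM to 100000 nM.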

Compound 4, half-maximal inhibitory concentration: 25500 nM
For compound 4 the middle estimate is 1.3-fold (0.11 log units) below the measured one; the range from low to high includes it.
By their numbers in this assay, from the lowest: compound 3; then compounds 4 and 1 (each within the scatter of the next). At a limit, above all of these: compound 2.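

Compound 2 is known only as a limit, not as a number: the limit of > 100000 nM in this assay, at which 1 of the 4 values shown sits. In this assay a second replacement of benzyl(methyl)amino gives an at least 3.9-fold lower number from compound 2 to compound 4 (0.59 log units; beyond the scatter), yet 4-(pyridin-4-yl)piperazin-1-yl does not match 4-phenylpiperidin-1-yl, with a 2.7-fold higher number from compound 3 to compound 4 (0.43 log units; beyond the scatter), so carrying a six-membered non-aromatic ring and an aromatic ring at the chain end does not alone fix the number here. Against diethylamino the new group gives a 2.0-fold lower number from compound 1 to compound 4 (0.30 log units; within the scatter), so compound 4 cannot be separated from compound 1 in this assay.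

The step to compound 4 alters both rings at once, and 4-phenylpiperazin-1-yl would show which ring change carries the loss. Open too, from the compounds shown here alone, is how a morpholine at the chain end, or a longer chain, would read.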